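A few compounds are considered here, and "the series" means these few. Any claim that something is new, unique, unknown or untested is made for them only; others in the source may bear on it.

Compound 1 `Cn1nc(CN2CCCC2)nc1-c1ccc2ccsc2c1` in an assay on membranes from Jurkat cells for displacement of a labelled ligand from Sigma intracellular receptor 2 (Homo sapiens), read by scintillation counting, with a stated time of 1 h (on this read-out higher numbers stand for weaker inhibition and lower numbers for stronger inhibition), gives > 1000 nM, which is a limit of the assay and not a number. Compound 2 `Cn1nc(CN2CCCC2)nc1-c1ccc(C2(C(F)(F)F)CC2)cc1` in this assay gives > 1000 nM, again a limit. Compound 3 `Cn1nc(CN2CCCC2)nc1-c1cccc(-c2ccccc2)c1` in this assay gives 1000 nM.

Compound 3 thus holds the only number shown, while the other two values sit at the limit of > 1000 nM in this assay, at which 2 of the 3 values shown sit. Compound 4 `Cn1nc(CN2CCCC2)nc1-c1cccc(C2(C(F)(F)F)CC2)c1` differs from compound 3 by 1-(trifluoromethyl)cyclopropyl in place of phenyl on an aromatic carbon. Within the data shown here, no step between measured compounds is available here, and compound 2, which carries the same 1-(trifluoromethyl)cyclopropyl group, gives only a limit in this assay. The step from compound 3 to compound 4 is expected to be a 2.0-fold higher number from compound 3 to compound 4 (0.30 log units; within the scatter), toward weaker inhibition. Compound 4 is expected to give 2000 nM, within 800 nM to 8000 nM, quite possibly reported only as a limit.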

Compound 4, inhibition constant: > 1000 nM
Compound 4 was reported as a limit (the forecaster's own chance of this, stated with the estimate: 65%); the middle value is on the limit's open side.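

Among these compounds, this is the first step that can be followed in this assay: on an aromatic carbon meta to a large group, 1-(trifluoromethyl)cyclopropyl in place of phenyl gives a number no lower from compound 3 to compound 4 (the limit leaves the size open). At this position, then, the change brings no stronger inhibition, although how much is lost cannot be read. The shown series still offers little to compare, and phenyl remains the only group here tied to an actual number: the limit of > 1000 nM in this assay, at which 3 of the 4 values shown sit.

Going by these compounds, how far compound 4 lies from compound 3 stays open. So does what an amine or a carboxylic acid would give at this position.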